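Phenyl in Place of Trifluoromethyl: What Efficacy to Expect

This account rests on a few compounds, and the source may have more. Where it says the series, first, only, none or still open, it means among the compounds named here.

Compound 2 `CN(C)CCC(OC(=O)c1ccc(C(F)(F)F)cc1)c1ccc(Cl)cc1` carries a trifluoromethyl group on an aromatic carbon of its benzoate part. Among the measured compounds shown here, in an assay on NIH3T3 cells with Urotensin-2 receptor (Homo sapiens) as the target (on this read-out higher numbers stand for larger maximal responses and lower numbers for smaller maximal responses), compound 2 gives 47%, the lower of the two numbers measured so far. For the measured compounds named here, its only measured neighbour, compound 1 `COc1ccc(C(=O)OC(CCN(C)C)c2ccc(Cl)cc2)cc1`, gives 84% in this assay, and the step of a number 37 percentage points lower from compound 1 to compound 2 (beyond the scatter) is the one change measured. Compound 3 `CN(C)CCC(OC(=O)c1ccc(-c2ccccc2)cc1)c1ccc(Cl)cc1` has not yet been measured; it differs from compound 2 by phenyl in place of trifluoromethyl on an aromatic carbon. Going by the values given here, the single measured step shows that exchanging the group on this aromatic carbon can shift the maximal response by a large amount, but that step concerns methoxy rather than phenyl, so its direction gives no firm guidance for compound 3. The estimate for compound 3 is therefore a step of a number 15 percentage points higher from compound 2 to compound 3 (beyond the scatter), a moderate expected rise with wide uncertainty, giving an expected value of 62% within a range of 35% to 90%.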

Compound 3, largest response reached (reported as efficacy), in percent of the reference or control that the assay uses: 53%
Compound 3: the middle estimate sits 9 percentage points above what was measured; low and high end bracket the measured number.
By their numbers in this assay, from the lowest: compounds 2 and 3 (each within the scatter of the next); then compound 1.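

In this assay, the exchange of trifluoromethyl for phenyl on this aromatic carbon gives a number 6 percentage points higher from compound 2 to compound 3 (within the scatter). The two groups therefore cannot be told apart on this read-out, although phenyl brings 6 heavy atoms and a six-membered aromatic ring where trifluoromethyl has 4 heavy atoms and no ring. The second new comparison, a number 31 percentage points lower from compound 1 to compound 3 (beyond the scatter), shows that a second group in place of methoxy also lies beyond the scatter from compound 1, so among these three compounds methoxy alone stands apart.

Nothing available here explains why methoxy stands apart from the other two groups. As far as these compounds go, whether the higher maximal response belongs to methoxy alone stays open, and an ethoxy group, a hydroxyl group or an amine at this place would be needed to show it.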